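The compounds below may be only part of what the source reports. "The series", "measured", "known", "first", "only" and "open" are said of these compounds alone.

Three compounds have been measured in a functional assay on MCF7 cells (Homo sapiens) for antiproliferative activity, read by MTT assay, with a stated time of 72 h; on this read-out higher numbers stand for weaker inhibition and lower numbers for stronger inhibition:
Compound 1, `CC/C=C/C(=O)Nc1cc2c(N3CCc4ccccc43)ncnc2cc1OC`, gives 4030 nM.
Compound 2, `CCC/C=C/C(=O)Nc1cc2c(N3CCc4ccccc43)ncnc2cc1OC`, gives 3160 nM.
Compound 3, `CC/C=C/C(=O)Nc1cc2c(N3CCCc4ccccc43)ncnc2cc1OC`, gives 2870 nM.

Compound 2 differs from compound 1 by methyl in place of hydrogen on a saturated chain carbon, two bonds along the chain from a double-bonded chain carbon, and this change gave a 1.3-fold lower number from compound 1 to compound 2 (0.11 log units; within the scatter). Compound 3 and compound 1 have different cores; that difference is not broken down here, and their two values lie within the usual scatter of each other.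

Compound 4, `COc1cc2ncnc(N3CCCc4ccccc43)c2cc1NC(=O)/C=C/C(C)C`, has not yet been measured. It differs from compound 3 by methyl in place of hydrogen on a saturated chain carbon bound to a double-bonded chain carbon and a saturated chain carbon. Among the measured compounds shown here, this is the same kind of change as the one made from compound 1 to compound 2, but not the same: there the methyl entered on a saturated chain carbon, two bonds along the chain from a double-bonded chain carbon, here it enters on a saturated chain carbon bound to a double-bonded chain carbon and a saturated chain carbon. Because the earlier methyl gave only a 1.3-fold lower number from compound 1 to compound 2 (0.11 log units; within the scatter), a similarly small step is expected here, a 1.1-fold lower number from compound 3 to compound 4 (0.06 log units; within the scatter), though the different place adds uncertainty. Compound 4 is therefore estimated at 2500 nM in this assay, with a likely range from 1100 nM to 5800 nM.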

Compound 4, half-maximal inhibitory concentration: 4290 nM
Compound 4: the middle estimate sits 1.7-fold (0.23 log units) below what was measured, within the range that was stated.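

Adding the methyl to the core of compound 3, which turns but-1-en-1-yl into 3-methylbut-1-en-1-yl, gave a 1.5-fold higher number from compound 3 to compound 4 (0.17 log units; within the scatter). Set beside the earlier methyl step, this step shows no real difference between the two cores: the same change on two cores in this assay, a 1.3-fold lower number (0.11 log units; within the scatter) from compound 1 to compound 2 and a 1.5-fold higher number (0.17 log units; within the scatter) from compound 3 to compound 4, 1.9-fold (0.28 log units) apart, within the scatter of two such steps. In this assay, neither step can be told apart from repeat noise, so the methyl shows no clear effect on either core, but this does not show that an effect would carry from one core to the other, and the methyl also sits on a different chain carbon in each pair.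

The compounds shown leave open what an amine, a carboxylic acid or a longer chain in place of this methyl would do. They also leave open whether any step beyond the scatter would hold on both cores.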